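The source may hold more compounds than are shown below. What is called first, only, known or untested is meant among the compounds shown, and "the series" means these compounds.

Working notes on the series. Compound 2 `CCCC(Nc1cncc(-c2ccc(O)c(OC)c2)n1)c1ccc(Cl)cc1` and compound 1 `CC[C@H](Nc1cncc(-c2ccc(O)c(OC)c2)n1)c1ccccc1` share a core and differ in the saturated chain and in the substituted phenyl on the chain carbon. In a functional assay on PC-3 cells (Homo sapiens) for cytotoxicity, read by MTT assay, with a stated time of 72 h (a higher number here means a weaker inhibitor, a lower number a stronger inhibitor), compound 2 gives 20000 nM. In this assay compound 1 gives 10000 nM; the two numbers lie within the scatter of each other, so nothing separates compound 1 from compound 2 on this read-out. Compound 3 `CCCC(Nc1cncc(-c2ccc(O)c(OC)c2)n1)c1cccc(Cl)c1` is not yet measured; relative to compound 2 the change is 3-chlorophenyl in place of 4-chlorophenyl on a saturated chain carbon bound to a nitrogen on an aromatic ring and a saturated chain carbon. Among the measured compounds shown here, no pair in the set tests this kind of change, so there is no measured step to lean on. With both measured numbers sitting close together, a positional swap of the chlorine is expected to give a step from compound 2 to compound 3 of no change at the digits printed from compound 2 to compound 3 (within the scatter), in either direction, not beyond the scatter. Compound 3 is therefore estimated at 20000 nM, with a range from 8000 nM to 50000 nM.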

Compound 3, half-maximal inhibitory concentration: 1000 nM
For compound 3 the middle estimate is 20-fold (1.30 log units) above the measured one, outside the stated range (below it).
By their numbers in this assay, from the lowest: compound 3; then compounds 1 and 2 (each within the scatter of the next).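

In this assay, a swap that only moves the chlorine, 3-chlorophenyl in place of 4-chlorophenyl on a saturated chain carbon bound to a nitrogen on an aromatic ring and a saturated chain carbon, gives a 20-fold lower number from compound 2 to compound 3 (1.30 log units; beyond the scatter) and so shows that this position responds strongly to where the chlorine sits on the phenyl, although the heavy atoms counted for the two groups are the same. Compound 1 and compound 2 differ in two places and lie within the scatter of each other, so that pair gave no sign of this sensitivity. Nothing measured here accounts for the step.

Open, from the compounds shown here alone, is whether a bromine or a trifluoromethyl group carried in the place of the chlorine of compound 3 would keep the number of compound 3. Also open, going by these compounds, is whether the same chlorine move would give a similar step on the saturated chain of compound 1, or on other cell lines.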